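The source may hold more compounds than are shown below. What is called first, only, known or untested is meant among the compounds shown, and "the series" means these compounds.

Compound 1 `COc1cc(/C=C/C(=O)C2=C(/C=C/c3ccc(O)c(OC)c3)NC(=O)NC2c2ccccc2)ccc1O`: 20%
Compound 2 `COc1cc(/C=C/C(=O)C2=C(/C=C/c3ccc(O)c(OC)c3)NC(=O)NC2c2ccccc2O)ccc1O`: 71%
Compound 3 `COc1cc(/C=C/C(=O)C2=C(/C=C/c3ccc(O)c(OC)c3)NC(=S)NC2c2ccccc2)ccc1O`: 22%

All three numbers come from a functional assay, with a stated time of 20 min, tested at 10 uM; on this read-out lower numbers stand for a weaker effect and higher numbers for a stronger effect at the one concentration tested. Compound 3 stands second highest of the three; its nearest neighbour is compound 1, whose number lies within the scatter of it, while compound 2 lies far above both. Compound 4 `COc1cc(/C=C/C(=O)C2=C(/C=C/c3ccc(O)c(OC)c3)NC(=S)NC2c2c(Cl)cccc2Cl)ccc1O` has not yet been measured. It differs from compound 3 in one place: 2,6-dichlorophenyl in place of phenyl on a saturated ring carbon. For the measured compounds named here, the only measured step between two compounds that differ in one place is a number 51 percentage points higher from compound 1 to compound 2 (beyond the scatter), where a hydroxy replaces hydrogen on an aromatic carbon of the same phenyl that is exchanged here. That step shows that a change on this ring can move the read-out a great deal. Going by the values given here, two chlorine atoms are not a hydroxy, and no measured pair shows what they do, so the direction stays open. The expectation for compound 4 is a modest rise, a number 13 percentage points higher from compound 3 to compound 4 (beyond the scatter), with wide uncertainty. Compound 4 is estimated at 35%, expected to fall between 10% and 75%.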

Compound 4, a percentage reported as activity, at one concentration (the size of the read-out at that concentration, not a potency): 20.2%
Compound 4: middle estimate off by 14.8 percentage points, on the high side; the measured number falls inside the stated range.
By their numbers in this assay, from the lowest: compounds 1, 4 and 3 (each within the scatter of the next); then compound 2.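

In this assay the exchange of phenyl for 2,6-dichlorophenyl gives a number 1.8 percentage points lower from compound 3 to compound 4 (within the scatter), so two chlorine atoms on this ring leave the number within the scatter of the unsubstituted phenyl. For the compounds shown here, until now, the only step at this ring was the hydroxy step (a number 51 percentage points higher from compound 1 to compound 2 (beyond the scatter)), and this result shows that a substituent on the ring does not by itself bring such a large rise, at least when the substituent is chlorine and the core is that of compound 3. Nothing measured here explains why the hydroxy and the two chlorine atoms behave differently.

As far as these compounds go, it remains open whether a hydroxy on the phenyl of compound 3 would bring the same rise that it brings in compound 2. From the compounds shown here alone, it is also open whether a single chlorine, a methoxy or an amine on this ring would follow the hydroxy or the two chlorine atoms.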